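The compounds below may be only part of what the source reports. "The series", "measured", "known", "first", "only" and "open" are said of these compounds alone.

Working notes on the series in a functional assay on MCF7 cells (Homo sapiens) for antiproliferative activity, read by MTT assay, with a stated time of 48 h; on this read-out lower numbers stand for stronger inhibition and higher numbers for weaker inhibition. Compound 1 `Cc1ccc(Cl)cc1-n1nncc1CN1C(=O)C2(C(C#N)=C(N)Oc3c2c2nc4ccccc4nc2c2ccccc32)c2ccccc21` returns only a limit of the assay, > 50000 nM. Compound 2 `N#CC1=C(N)Oc2c(c3nc4ccccc4nc3c3ccccc23)C12C(=O)N(Cc1cnnn1-c1cc(Cl)ccc1Cl)c1ccccc12` likewise returns only a limit, > 50000 nM. The step from compound 1 to compound 2, a step that the two limits leave unreadable from compound 1 to compound 2, is therefore not readable, since both values sit at the limit of > 50000 nM in this assay, at which 2 of the 3 values shown sit. For the measured compounds named here, compound 3 `CCc1ccccc1-n1nncc1CN1C(=O)C2(C(C#N)=C(N)Oc3c(N)cc4nc5ccccc5nc4c32)c2ccccc21` gives 24600 nM in this assay, the only number among the three values shown. Compound 3 therefore cannot be ranked against compound 1 or compound 2.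

Compound 4 `N#CC1=C(N)Oc2c(N)cc3nc4ccccc4nc3c2C12C(=O)N(Cc1cnnn1-c1c(F)cccc1F)c1ccccc12` differs from compound 3 in one place: 2,6-difluorophenyl in place of 2-ethylphenyl on an aromatic nitrogen. Going by the values given here, the only measured step, a step that the two limits leave unreadable from compound 1 to compound 2, also alters the aryl group on that aromatic nitrogen, but it runs between two limits and yields no size. No readable step therefore bears on the change from compound 3 to compound 4, and no movement beyond the usual scatter of this assay is expected in either direction. Compound 4 is expected to give about 25000 nM, within 10000 nM to 60000 nM, which corresponds to an expected step of a 1.0-fold higher number from compound 3 to compound 4 (0.01 log units; within the scatter). Because compound 3 sits not far from the limit of > 50000 nM in this assay, at which 2 of the 3 values shown sit, there is a fair chance that compound 4 returns only a limit.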

Compound 4, half-maximal inhibitory concentration: > 50000 nM
Compound 4 was reported as a limit; the forecaster's own chance of this, stated with the estimate: 30%; middle value at least 2.0-fold (0.30 log units) from the limit.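

For the compounds shown here, this is the first step at this position on the aromatic nitrogen with a bound on its size in this assay: 2,6-difluorophenyl in place of 2-ethylphenyl gives an at least 2.0-fold higher number from compound 3 to compound 4 (0.30 log units; that floor lies within the scatter). The floor of that step lies within the usual scatter, so the change cannot be called a real loss, although a measured number now stands only with 2-ethylphenyl among the aryl groups shown; the step between the two earlier limits, compound 1 and compound 2, remains unreadable. The readable range of the series has narrowed further, and this position can now be judged from one compound alone: the limit of > 50000 nM in this assay, at which 3 of the 4 values shown sit.

Going by these compounds, how far compound 4 actually lies from compound 3 stays open, as does whether any other aryl group on this nitrogen returns a number at all. An unsubstituted phenyl, a 2-methoxyphenyl or a 2-propylphenyl in the same place would show whether a number in this assay goes with the 2-ethylphenyl group alone or extends to other groups on the core of compound 3.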